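This account rests on a few compounds, and the source may have more. Where it says the series, first, only, none or still open, it means among the compounds named here.

Measured compounds:
compound 1 `Cn1c(Sc2c(F)cc(C(=O)NO)cc2F)nnc1-c1cccs1` — 9 nM
compound 2 `O=C(NO)c1ccc(Cn2nnc(-c3ccccn3)n2)cc1` — 9 nM

In an assay on Sf9 cells for inhibition of protein deacetylase HDAC6 (Homo sapiens), read by fluorescence (on this read-out lower numbers stand for stronger inhibition and higher numbers for weaker inhibition), compound 1 gives 9 nM. Compound 2, built on a different core, gives 9 nM in this assay, and the two values stand level within the scatter, so neither compound can be called the stronger inhibitor. Compound 3 `Cc1cc(-c2nnc(Sc3c(F)cc(C(=O)NO)cc3F)n2C)nn1C` is compound 1 with 1,5-dimethyl-1H-pyrazol-3-yl in place of thiophen-2-yl on an aromatic carbon. Among the measured compounds shown here, no pair of measured compounds isolates this exchange, and compound 2 differs from compound 1 in several places at once, so it offers no direct guide. With the shared core of compound 1 left untouched, only a small step is expected, at most a slight drift toward weaker inhibition, within or barely beyond the scatter; the step of a 1.3-fold higher number from compound 1 to compound 3 (0.12 log units; within the scatter) is the expected size. Compound 3 is therefore expected to give 12 nM, with a range from 4 nM to 40 nM.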

Compound 3, half-maximal inhibitory concentration: 6 nM
Compound 3: the middle estimate sits 2.0-fold (0.30 log units) above what was measured; the range from low to high includes it.
By their numbers in this assay, from the lowest: compounds 3, 1 and 2 (each within the scatter of the next).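

In this assay, 1,5-dimethyl-1H-pyrazol-3-yl in place of thiophen-2-yl on this aromatic carbon gives a 1.5-fold lower number from compound 1 to compound 3 (0.18 log units; within the scatter), the only direct reading of an exchange at this position among the compounds shown. The position therefore takes a ring with 2 hetero atoms and 7 heavy atoms in place of a ring with 1 hetero atom and 5 heavy atoms, sulfur giving way to nitrogen, with no change beyond the scatter. No available measurement bears on what lies behind this result.

The compounds shown leave open whether this position would give a similar reading with a group other than a five-membered aromatic ring, such as an amine, a carboxylic acid or a longer alkyl chain. They also leave open whether the same exchange would read alike on a different core.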